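The source may hold more compounds than are shown below. What is called first, only, known or untested is meant among the compounds shown, and "the series" means these compounds.

Compound 2 `C[C@@H](NC(=O)Nc1ccccc1F)c1ccccc1` stands at the top of two numbers in an ADME assay on the whole organism with Oryza sativa as the target, tested at 0.1 uM (on this read-out higher numbers stand for a weaker effect at the one concentration tested and lower numbers for a stronger effect), where compound 2 gives 97%, within the scatter of compound 1 `CC(=O)c1ccccc1NC(=O)N[C@H](C)c1ccccc1`, which gives 96% in this assay. Going by the values given here, the single measured step, a number 1 percentage points higher from compound 1 to compound 2 (within the scatter), was within the scatter. Compound 3 `C[C@@H](NC(=O)Nc1ccccc1Cl)c1ccccc1` differs from compound 2 as chloro in place of fluoro on an aromatic carbon, a change at the same place as that step, so no movement beyond the scatter is expected in this assay in either direction. Compound 3 is expected to give about 96%, ranging from 86% to 100%. The estimated step is a number 1 percentage points lower from compound 2 to compound 3 (within the scatter).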

Compound 3, a percentage reported as activity, at one concentration (the size of the read-out at that concentration, not a potency): 101%
For compound 3 the middle estimate is 5 percentage points below the measured one; measured number outside the range, above it.
By their numbers in this assay, from the lowest: compounds 1, 2 and 3 (each within the scatter of the next).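

Chloro in place of fluoro gives a number 4 percentage points higher from compound 2 to compound 3 (within the scatter) in this assay, and chloro in place of acetyl gives a number 5 percentage points higher from compound 1 to compound 3 (within the scatter) on the same read-out. Acetyl, fluoro and chloro on this aromatic carbon, ortho to a large group, therefore all lie within the scatter of one another, so the halogen exchange adds a third group without separating the compounds. Nothing available explains the read-out at this position. On these data alone, whether an amine, a carboxylic acid or a methoxy group here would move the number beyond the scatter remains open. So does whether a change elsewhere on the shared core would do so.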